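Chloro on the Benzyl Ring: Tolerance of Compound 4

This account rests on a few compounds, and the source may have more. Where it says the series, first, only, none or still open, it means among the compounds named here.

Measured compounds:
Compound 1, `CCN(Cc1ccccc1)C(=O)C1CCN(CCCN(C(=O)C2CCN(C(C)=O)CC2)c2ccc(C)c(Cl)c2)CC1`, 83.9 nM
Compound 2, `CC(=O)N1CCC(C(=O)N(CCCN2CCN(Cc3ccncc3)CC2)c2ccc(C)c(Cl)c2)CC1`, > 56700 nM
Compound 3, `CC(=O)N1CCC(C(=O)N(CCCN2CCN(Cc3ccccc3)CC2)c2ccc(C)c(Cl)c2)CC1`, 101000 nM

In an ADME assay (Homo sapiens) for cytotoxicity (a lower number here means that less compound is tolerated, a higher number that more compound is tolerated), compound 3 gives 101000 nM, the highest of the two numbers shown. Compound 1 stands far lower at 83.9 nM. Compound 2 reaches only a limit of the assay, > 56700 nM, as noted in the limit of > 56700 nM in this assay, at which 1 of the 3 values shown sits. The step that the limit leaves unreadable from compound 2 to compound 3 is therefore not readable in size.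

Compound 4, `CC(=O)N1CCC(C(=O)N(CCCN2CCN(Cc3ccc(Cl)cc3)CC2)c2ccc(C)c(Cl)c2)CC1`, differs from compound 3 by chloro in place of hydrogen on an aromatic carbon, para to a large group on the ring. For the measured compounds named here, no measured step touches this ring position; the one step between compounds that differ in a single place runs into the limit and gives no size. The shared core of compound 3 and compound 4 is otherwise unchanged.

With nothing to point the other way, the step of a 1.3-fold lower number from compound 3 to compound 4 (0.10 log units; within the scatter) is expected to stay within the scatter. Compound 4 is estimated at 80000 nM in this assay, with a range from 30000 nM to 160000 nM.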

Compound 4, half-maximal cytotoxic concentration: 37600 nM
Beside the measured number, compound 4's estimate is 2.1-fold (0.33 log units) above it; the range from low to high includes it.
By their numbers in this assay, from the lowest: compound 1; then compound 4; then compound 3.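

In this assay, the change from benzyl to 4-chlorobenzyl gives a 2.7-fold lower number from compound 3 to compound 4 (0.43 log units; beyond the scatter), a modest step and the first readable size for any change on this ring. Set against the pyridin-4-yl of compound 2, the 4-chlorophenyl gives an at least 1.5-fold lower number from compound 2 to compound 4 (0.17 log units; that floor lies within the scatter), so only a floor is known for that exchange, and that floor does not clear the scatter. Compound 2 stands at a limit of the assay and not at a number: the limit of > 56700 nM in this assay, at which 1 of the 4 values shown sits.

The compounds shown leave open whether a fluoro or a methoxy on the same aromatic carbon would also lower the number, or whether this step belongs to chloro alone. They also leave open how phenyl itself compares with pyridin-4-yl; the step between those two compounds cannot be read.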